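A few compounds are considered here, and "the series" means these few. Any claim that something is new, unique, unknown or untested is made for them only; others in the source may bear on it.

Compound 1 `O=C(Nc1ccc(Cl)cc1)Nc1ccc(C(=O)/C=C/c2ccccc2)cc1` carries a urea link between two aromatic rings and a chalcone-type chain. In a functional assay on the whole organism (Abdomen, strain Swiss) with Mus musculus as the target, with a stated time of 30 min (on this read-out lower numbers stand for an effect already at smaller amounts and higher numbers for an effect only at larger amounts of compound), compound 1 gives 7.25 umol/kg. Compound 2 `O=C(/C=C/c1ccc(Cl)c(Cl)c1)c1ccc(NC(=S)Nc2ccc(Cl)cc2)cc1`, which has a thiourea link instead, gives 6.15 umol/kg in this assay, a number within the scatter of compound 1. Compound 3 `O=C(/C=C/c1ccccc1)c1ccc(NC(=S)Nc2ccc(Cl)cc2)cc1` gives 3.03 umol/kg, a number beyond the scatter below compound 1. Compounds 2 and 3 differ in a single place, and that step shows a 2.0-fold lower number from compound 2 to compound 3 (0.31 log units; beyond the scatter).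

Compound 4 `Cc1ccc(/C=C/C(=O)c2ccc(NC(=O)Nc3ccc(Cl)cc3)cc2)cc1` has not yet been measured. It differs from compound 1 in one place: methyl in place of hydrogen on an aromatic carbon. Among the measured compounds shown here, no measured pair shows methyl in place of hydrogen, so the only guidance is the step from compound 2 to compound 3, where phenyl in place of 3,4-dichlorophenyl on the chain lowered the number modestly; compound 4 goes the other way, from phenyl to 4-methylphenyl, so a small rise or no step beyond the scatter is expected. Compound 4 is estimated at 9 umol/kg, with a range from 4.5 umol/kg to 18 umol/kg, which means an expected step of a 1.2-fold higher number from compound 1 to compound 4 (0.09 log units; within the scatter).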

Compound 4, dose for 50% inhibition: 39.7 umol/kg
Compound 4: the middle estimate sits 4.4-fold (0.64 log units) below what was measured; measured number outside the range, above it.
By their numbers in this assay, from the lowest: compound 3; then compounds 2 and 1 (each within the scatter of the next); then compound 4.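

In this assay the added methyl on the terminal ring gives a 5.5-fold higher number from compound 1 to compound 4 (0.74 log units; beyond the scatter) and so shows that this aromatic carbon, para to a large group, responds strongly to a single extra heavy atom. The earlier step on this ring, a 2.0-fold lower number from compound 2 to compound 3 (0.31 log units; beyond the scatter) in the thiourea-linked compounds, exchanged 3,4-dichlorophenyl for phenyl and gave no view of a methyl here or of a change on the urea-linked compounds. No measured evidence is available to explain the size of this rise.

Going by these compounds, it remains open whether the rise is particular to methyl or would also appear with a methoxy group, an ethyl group or an amine at the same carbon. Also open, on these data alone, is whether the same methyl would raise the number of compound 3 to a similar degree.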